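Oxime series: methoxy in place of chloro

This account rests on a few compounds, and the source may have more. Where it says the series, first, only, none or still open, it means among the compounds named here.

Measured compounds:
compound 1 `O/N=C(\C=C\c1ccc(Cl)cc1)c1ccc(Cl)cc1` gives 9150 nM in a functional assay (Mus musculus, strain Balb/c) for inhibition, read by ELISA, with a stated time of 72 h; a higher number here means a weaker inhibitor, a lower number a stronger inhibitor.
compound 2 `COc1ccc(/C=C/C(=N\O)c2ccc(Br)cc2)cc1` gives only a limit of the assay, < 5000 nM, in this assay.
compound 3 `Cc1ccc(C(/C=C/c2ccc(Cl)cc2)=N/O)cc1` gives 11600 nM in this assay.

Compound 3 holds the highest of the two numbers; its nearest neighbour is compound 1, and the step of a 1.3-fold higher number from compound 1 to compound 3 (0.10 log units; within the scatter) is within the scatter. The third value, that of compound 2, is a limit rather than a number (the limit of < 5000 nM in this assay, at which 1 of the 3 values shown sits).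

Compound 4 `COc1ccc(/C=C/C(=N\O)c2ccc(C)cc2)cc1` differs from compound 3 by methoxy in place of chloro on an aromatic carbon. For the measured compounds named here, no measured step carries this exact change. Going by the values given here, the one measured step, a 1.3-fold higher number from compound 1 to compound 3 (0.10 log units; within the scatter), is methyl in place of chloro on an aromatic carbon, a different change, and it is within the scatter. The basis for an expectation is compound 2, which also carries methoxy and reaches only the limit (the limit of < 5000 nM in this assay, at which 1 of the 3 values shown sits). Compound 4 is therefore expected to give a lower number than compound 3, the estimated step being a 2.3-fold lower number from compound 3 to compound 4 (0.37 log units; beyond the scatter), with a fair chance that only a limit is reported again. Compound 4 is estimated at 5000 nM in this assay, between 2000 nM and 13000 nM.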

Compound 4, half-maximal inhibitory concentration: 6240 nM
Beside the measured number, compound 4's estimate is 1.2-fold (0.10 log units) below it, within the range that was stated.
By their numbers in this assay, from the lowest: compounds 4, 1 and 3 (each within the scatter of the next). At a limit, below all of these: compound 2.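

In this assay, methoxy in place of chloro on an aromatic carbon, para to a large group, can now be read directly: a 1.9-fold lower number from compound 3 to compound 4 (0.27 log units; within the scatter), so this change at this position is not resolved from no change at all. With methoxy held fixed, methyl in place of bromo gives only a floor, an at least 1.2-fold higher number from compound 2 to compound 4 (0.09 log units; that floor lies within the scatter), and that floor does not separate the two groups. Compound 2 remains a limit and not a number: the limit of < 5000 nM in this assay, at which 1 of the 4 values shown sits.

From the compounds shown here alone, whether any group at this position moves the number beyond the scatter stays open; an amine, a carboxylic acid or a longer chain such as ethoxy in place of methoxy would test this. Also open is how far the number depends on the oxime itself, which all the compounds shown carry.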